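Methoxy for Fluoro on the Benzyl Arm

The compounds below may be only part of what the source reports. "The series", "measured", "known", "first", "only" and "open" are said of these compounds alone.

Of the compounds shown here, three built on one shared core have been tested in a functional assay on HOP-62 cells (Homo sapiens) for inhibition, read by sulforhodamine B assay, with a stated time of 48 h; on this read-out lower numbers stand for stronger inhibition of growth and higher numbers for weaker inhibition of growth. Compound 1 `Nc1cc(N)c2nc(-c3ccccc3)c(NCc3ccc(Cl)c(Cl)c3)nc2c1` gives 31600 nM, and compound 2 `COc1ccc(CNc2nc3cc(N)cc(N)c3nc2-c2ccccc2)cc1OC` gives 34700 nM, so that the step of a 1.1-fold higher number from compound 1 to compound 2 (0.04 log units; within the scatter) leaves the read-out unchanged within scatter. For compound 3 `Nc1cc(N)c2nc(-c3ccccc3)c(NCc3ccc(F)cc3)nc2c1` only a limit is known, < 100000 nM in this assay, (the limit of < 100000 nM in this assay, at which 1 of the 3 values shown sits). Accordingly the steps a step that the limit leaves unreadable from compound 1 to compound 3 and a step that the limit leaves unreadable from compound 2 to compound 3 cannot be sized. Compound 4 `COc1ccc(CNc2nc3cc(N)cc(N)c3nc2-c2ccccc2)cc1` carries one further change: methoxy in place of fluoro on an aromatic carbon. Among the measured compounds shown here, no measured step reads on this exact change, and compound 3 stands at a limit, so the step is expected as a step that the limit leaves unreadable from compound 3 to compound 4 without a readable anchor. The estimate rests instead on compounds 1 and 2, whose benzyl substituents scarcely moved the number. Compound 4 is therefore expected to give 35000 nM, within a range from 12000 nM to 100000 nM.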

Compound 4, concentration for total growth inhibition: 34700 nM
Compound 4: the middle estimate sits 1.0-fold (0.00 log units) above what was measured; the measured number falls inside the stated range.
By their numbers in this assay, from the lowest: compounds 1, 2 and 4 (each within the scatter of the next).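

In this assay, the 4-methoxybenzyl arm gives a third readable benzyl group: hydrogen in place of methoxy is no change at the digits printed from compound 2 to compound 4 (within the scatter), and 4-methoxyphenyl in place of 3,4-dichlorophenyl is a 1.1-fold higher number from compound 1 to compound 4 (0.04 log units; within the scatter). Compound 1, compound 2 and compound 4 thus sit within the scatter of one another, whichever of these substituents the arm carries. The steps to and from compound 3, including methoxy in place of fluoro, cannot be read, since compound 3 is known only as a limit: the limit of < 100000 nM in this assay, at which 1 of the 4 values shown sits.

Where compound 3 truly stands remains open. So does whether an amine or a carboxylic acid on the benzyl ring, or a longer chain in place of the benzyl arm, would move the number.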